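Shortening the hydroxamate chain on a shared core

The source may report more compounds than this note shows. Statements on the series, on what has been measured and on what is new or still open speak of the compounds shown alone.

Measured compounds:
compound 1, `Nc1ncnc2c1c(-c1cnc3[nH]ccc3c1)nn2CCCCCCC(=O)NO` — 99.1%
compound 2, `Nc1nc2cc(-c3nn(CCCCCCCCC(=O)NO)c4ncnc(N)c34)ccc2o1` — 99%

Of the compounds shown here, two have been measured in an assay on isolated protein for inhibition of protein deacetylase HDAC6 (Homo sapiens), with a stated time of 15 min, tested at 1 uM; on this read-out higher numbers stand for more inhibition at the one concentration tested (going by the name of the read-out) and lower numbers for less inhibition. Compound 1, `Nc1ncnc2c1c(-c1cnc3[nH]ccc3c1)nn2CCCCCCC(=O)NO`, gives 99.1%. Compound 2, `Nc1nc2cc(-c3nn(CCCCCCCCC(=O)NO)c4ncnc(N)c34)ccc2o1`, gives 99%. The two numbers lie within the usual scatter of each other, so compound 2 does not stand apart from compound 1; both numbers sit level, high on the read-out at the concentration tested.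

The next compound, compound 3, `Nc1nc2cc(-c3nn(CCCCCCC(=O)NO)c4ncnc(N)c34)ccc2o1`, keeps the core of compound 2 and differs from it only in the chain that carries the hydroxamic acid: hydroxycarbamoyl in place of 2-(hydroxycarbamoyl)ethyl on a saturated chain carbon, six bonds along the chain from an aromatic nitrogen. The chain of compound 3 thereby reaches the length of the chain in compound 1, which carries a different group on the other end of the core.

Among the compounds with values here, no step between measured compounds is available, so the size of the change from compound 2 to compound 3 can only be expected, not read off. Since compound 1, with a chain of this length, gives 99.1%, little movement beyond the scatter is expected. Compound 3 is therefore estimated at 97%, within a range from 88% to 100%, which means an expected step of a number 2 percentage points lower from compound 2 to compound 3 (within the scatter).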

Compound 3, a percentage reported as inhibition, at one concentration (the size of the read-out at that concentration, not a potency): 99%
Compound 3: middle estimate off by 2 percentage points, on the low side; low and high end bracket the measured number.
By their numbers in this assay, from the lowest: compounds 2, 3 and 1 (each within the scatter of the next).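

In this assay, hydroxycarbamoyl in place of 2-(hydroxycarbamoyl)ethyl on a saturated chain carbon, six bonds along the chain from an aromatic nitrogen, gives no change at the digits printed from compound 2 to compound 3 (within the scatter), so on this core the read-out does not separate the two chain lengths at the one concentration tested. With the chain length held the same, the exchange of the two groups on the aromatic carbon gives a number 0.1 percentage points lower from compound 1 to compound 3 (within the scatter), so that exchange is not separated either, and the earlier pair, which differed in more than one place, could not show either point. No measurement at hand bears on why these numbers sit level.

All three numbers lie high on a read-out taken at a single concentration, so it stays open whether potency differs among these compounds, which only a measurement across concentrations could show. Also open, going by these compounds, is what a much shorter chain, or a carboxylic acid in place of the hydroxamic acid at the chain end, would give on this core.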